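The source may report more compounds than this note shows. Statements on the series, on what has been measured and on what is new or still open speak of the compounds shown alone.

Compound 1 `CCn1c(C(=O)NCC(=O)O)ccc1C(CC)(CC)c1ccc(C#CC(O)(CC)CC)c(C)c1` gives 2250 nM in a functional assay on PC-3 cells (Homo sapiens) for antiproliferative activity, read by MTT assay, with a stated time of 72 h; a higher number here means a weaker inhibitor, a lower number a stronger inhibitor.
Compound 2 `CCn1c(C(=O)NCCC(=O)O)ccc1C(CC)(CC)c1ccc(C#CC(O)(CC)CC)c(C)c1` gives 5130 nM in this assay.
Compound 3 `CCn1cc(C(CC)(CC)c2ccc(C#CC(O)(CC)CC)c(C)c2)cc1C(=O)NCC(=O)O` gives 6300 nM in this assay.

Compound 1 and compound 2 share a core and differ only at the acid end of the amide side chain: carboxymethyl in place of carboxy on a saturated chain carbon bound to an amide-type nitrogen. That change made a 2.3-fold higher number from compound 1 to compound 2 (0.36 log units; beyond the scatter), a weakening. Compound 3 is built from the same atoms as compound 1 joined differently; the difference between the two cores is not broken down here. In this assay compound 3 stands higher than compound 1 by more than the scatter, while its number and that of compound 2 lie within the scatter of each other.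

Compound 4 `CCn1cc(C(CC)(CC)c2ccc(C#CC(O)(CC)CC)c(C)c2)cc1C(=O)NCCC(=O)O` is not yet measured. It relates to compound 3 exactly as compound 2 relates to compound 1: carboxymethyl in place of carboxy on a saturated chain carbon bound to an amide-type nitrogen, the same change at the same place. The expectation is that it moves the number in the same direction, so a step of a 2.2-fold higher number from compound 3 to compound 4 (0.35 log units; beyond the scatter) is estimated, set beside a 2.3-fold higher number from compound 1 to compound 2 (0.36 log units; beyond the scatter); this rests on that single earlier pair, so it is a loose guide. For compound 4 the estimate in this assay is 14000 nM, between 6500 nM and 32000 nM.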

Compound 4, half-maximal inhibitory concentration: > 50000 nM
Compound 4 was reported as a limit; the forecaster's own chance of this, stated with the estimate: 15%; at least 3.5-fold (0.55 log units) between middle value and limit.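

Going from carboxymethyl to 2-carboxyethyl on the saturated chain carbon bound to the amide-type nitrogen raises the number on both cores in this assay, so the direction of the change carries over to the core of compound 3 (an at least 7.9-fold higher number from compound 3 to compound 4 (0.89 log units; beyond the scatter)). The size of the change does not carry over, since the step on this core is clearly the larger of the two: the same change on two cores in this assay, a 2.3-fold higher number (0.36 log units; beyond the scatter) from compound 1 to compound 2 and an at least 7.9-fold higher number (0.89 log units; beyond the scatter) from compound 3 to compound 4, at least 3.4-fold (0.54 log units) apart, beyond the scatter of two such steps.

Compound 4 is reported only as a limit of the assay (> 50000 nM), not as a number, so the step on this core has a lower bound but no measured size, and these two pairs do not show why the cores respond differently.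

The compounds shown leave open whether a still longer chain ending in a carboxylic acid would raise the number further on either core. They also leave open how a methyl ester or a primary amide at the end of the chain would read on these two cores.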